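This account rests on a few compounds, and the source may have more. Where it says the series, first, only, none or still open, it means among the compounds named here.

Measured compounds:
- compound 1, `Oc1cccc(-c2cc(-c3ccc(Cl)cc3)nc(-c3ccco3)c2)c1`: 10200 nM
- compound 2, `Oc1cccc(-c2cc(-c3ccncc3)nc(-c3ccccc3Cl)c2)c1`: "not determined" (no result reported)

Compound 1 was tested in a functional assay on HCT-15 cells (Homo sapiens) for cytotoxicity, read by CCK-8 assay and cell counting, with a stated time of 2 days (a higher number here means a weaker inhibitor, a lower number a stronger inhibitor), and gives 10200 nM, a weak effect on cell growth. Compound 2 was run in this assay, where the result for compound 2 is "not determined" (no result reported), so compound 2 stands without a value and nothing can be said about how it compares with compound 1.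

The next compound is compound 3, `Oc1cccc(-c2cc(-c3ccco3)nc(-c3ccccc3Cl)c2)c1`, which has not yet been measured. It comes from compound 2 by a single change: furan-2-yl in place of pyridin-4-yl on an aromatic carbon. Since compound 2 has no number, the size of this step in this assay cannot be measured, and no direction can be read from the data. What remains as a guide is compound 1, which also carries the furan-2-yl group and a chlorophenyl group on the shared core. Because compound 1 gives 10200 nM in this assay, compound 3 is estimated to land near that level, at 10000 nM with a range from 3000 nM to 35000 nM. This is an expectation only, resting on one measured compound.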

Compound 3, half-maximal inhibitory concentration: 2230 nM
Compound 3: the middle estimate sits 4.5-fold (0.65 log units) above what was measured, and the stated range ends above it.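

Moving the chlorine around the phenyl ring turns out to matter: in this assay, a 4.6-fold lower number from compound 1 to compound 3 (0.66 log units; beyond the scatter), while the furan-2-yl and 3-hydroxyphenyl groups stay the same, so the 2-chlorophenyl compound is the stronger of this pair, by a modest margin that lies beyond the usual scatter. Among the compounds shown here, this is the first readable change, and it shows that the effect on these cells responds to where a single chlorine sits, although one pair cannot establish a general trend. The step from compound 2 to compound 3 cannot be read, as compound 2 has no number, so the swap of pyridin-4-yl for furan-2-yl remains unsized, and nothing available explains why the chlorine's location changes the result.

Going by these compounds, it remains open whether chlorine itself is important, or whether a plain phenyl, a 3-chlorophenyl or a 2-methoxyphenyl group in the same place would give a similar number. The role of the furan-2-yl group next to the ring nitrogen is also unsettled, and a thiophene ring or a simple amine there would help to test it.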